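The source may hold more compounds than are shown below. What is called first, only, known or untested is meant among the compounds shown, and "the series" means these compounds.

Measured so far:
- Compound 2, `Cc1cc(Cc2cccc(Cl)c2)c(=O)n(CC(=O)Nc2ccc(Br)cc2)n1`: in an assay on HL-60 cells for agonist activity at N-formyl peptide receptor 3 (Homo sapiens), read by calcium flux (on this read-out higher numbers stand for an effect only at larger amounts of compound and lower numbers for an effect already at smaller amounts), compound 2 gives > 50000 nM, which is a limit of the assay, not a number.
- Compound 3, `Cc1cc(Cc2cccc(Cl)c2)c(=O)n(CC(=O)Nc2ccc(I)cc2)n1`: in this assay compound 3 gives > 50000 nM, again a limit.
- Compound 1, `COc1ccc(Cc2cc(-c3ccc(C)cc3)nn(CC(=O)Nc3ccc(Br)cc3)c2=O)cc1`: in this assay compound 1 gives > 50000 nM, also a limit.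

Compound 2 therefore stands at the limit, and it cannot be placed against the others, since every value shown sits at the limit of > 50000 nM in this assay, at which 3 of the 3 values shown sit. Among the compounds with values here, the one step between measured compounds, a step that the two limits leave unreadable from compound 2 to compound 3, is unreadable for the same reason.

Compound 4, `Cc1cc(N)c(=O)n(CC(=O)Nc2ccc(Br)cc2)n1`, arises from compound 2 through (amino in place of 3-chlorobenzyl on an aromatic carbon). Within the data shown here, no measured step touches this change, and the only step that exists gives no size. The expectation therefore rests on the limits alone: the most likely outcome is that compound 4 also reports a limit rather than a number. On that footing the estimate for compound 4 is 50000 nM, with a range from 20000 nM to 100000 nM. The expected step from compound 2 to compound 4 is a number no higher from compound 2 to compound 4 (the limit leaves the size open), that is, none that can be read.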

Compound 4, half-maximal effective concentration: > 50000 nM
Compound 4: no number, only a limit; the forecaster's own chance of this, stated with the estimate: 85%; the middle value lies on the limit itself.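

In this assay compound 4 gives > 50000 nM, again a limit and not a number. The change from compound 2 to compound 4 therefore cannot be read as a step of any size: the limit of > 50000 nM in this assay, at which 4 of the 4 values shown sit.

The compounds shown leave open whether any change to the shared core gives a readable number.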